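The source may report more compounds than this note shows. Statements on the series, on what has been measured and on what is new or still open speak of the compounds shown alone.

Working notes on the sulfone series in an ADME assay on microsomes from liver (Homo sapiens) for metabolic stability, tested at 2.5 uM; a higher number here means faster removal of the compound, a lower number slower removal.

Compound 1, `COc1ccc(-c2c(S(=O)(=O)c3cccc(F)c3)cnc3cc(F)ccc23)cc1`, gives 1.89 mL/min in this assay. Among the compounds with values here, it stands highest of the three numbers measured so far. Compound 2, `O=S(=O)(c1cccc(F)c1)c1cnc2cc(F)ccc2c1-c1ccc(Cl)cc1`, gives 0.98 mL/min, and the change a 1.9-fold lower number from compound 1 to compound 2 (0.29 log units; within the scatter) stays within the scatter. Compound 3, `O=S(=O)(c1cccc(F)c1)c1cnc2cc(F)ccc2c1-c1ccc(F)cc1`, gives 0.11 mL/min, and the change a 17-fold lower number from compound 1 to compound 3 (1.24 log units; beyond the scatter) is large; between the two halogen analogues the change an 8.9-fold lower number from compound 2 to compound 3 (0.95 log units; beyond the scatter) is also beyond the scatter.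

Compound 4, `COc1ccc(-c2c(S(=O)(=O)c3ccc(F)c(Cl)c3)cnc3cc(F)ccc23)cc1`, is not yet measured. Its difference from compound 1 is 3-chloro-4-fluorophenyl in place of 3-fluorophenyl on a sulfonyl sulfur. All three measured steps alter the group on the aryl attached to the core, not the aryl on the sulfonyl sulfur, so none of them bears directly on this change; the only guidance is that a single added aromatic halogen has moved this assay by amounts ranging from within the scatter to large, and the direction on the sulfonyl aryl is not shown by any pair.

Within the data shown here, with no comparable step to lean on, compound 4 is expected to stay near compound 1, and the expected step of a 1.1-fold lower number from compound 1 to compound 4 (0.05 log units; within the scatter) is within the scatter. The estimate for compound 4 is therefore 1.7 mL/min, with a range from 0.6 mL/min to 4.5 mL/min.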

Compound 4, intrinsic clearance in a liver preparation (reported as CLH), per the amount of preparation that the assay uses: 1.08 mL/min
Compound 4: middle estimate off by 1.6-fold (0.20 log units), on the high side, and the stated range covers the measured number.
By their numbers in this assay, from the lowest: compound 3; then compounds 2, 4 and 1 (each within the scatter of the next).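

In this assay, the sulfonyl sulfur now has its first direct pair: 3-chloro-4-fluorophenyl in place of 3-fluorophenyl, with one more heavy atom in the entering group, gives a 1.8-fold lower number from compound 1 to compound 4 (0.24 log units; within the scatter). In this single pair, on the methoxy-bearing background, the change at the sulfonyl sulfur therefore stays inside the scatter, whereas the swap of methoxy for fluoro on the aryl attached to the core gave a 17-fold lower number from compound 1 to compound 3 (1.24 log units; beyond the scatter). No measurement shown here offers an explanation for the small size of this step.

The entering group differs from the leaving one in more than a single feature, and no compound shown separates what its chlorine and its fluorine each contribute, nor shows whether the same swap stays within the scatter on the fluoro or chloro background of compound 3 or compound 2. Also open, from the compounds shown here alone, is how this assay responds to a quite different group on the sulfonyl aryl, such as an amine or a carboxylic acid.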